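Flavor of a ceiling: the step from compound 2 to compound 3

The compounds below may be only part of what the source reports. "The series", "measured", "known", "first", "only" and "open" are said of these compounds alone.

Measured in a functional assay on Malme-3M cells (Homo sapiens) for cytotoxicity, read by MTT assay, with a stated time of 6 days; on this read-out lower numbers stand for an effect already at smaller amounts and higher numbers for an effect only at larger amounts of compound:
- compound 1 `O=c1cc(-c2ccc([N+](=O)[O-])cc2)oc2cc(O)ccc12`: > 25 ug/mL (a limit)
- compound 2 `Nc1ccc(-c2cc(=O)c3ccc(O)cc3o2)cc1`: > 25 ug/mL (a limit)

Compound 2 has no number on this read-out, and its entry of > 25 ug/mL is a limit. For the measured compounds named here, the one further value, for compound 1, is also a limit. Going by the values given here, the position so far is the limit of > 25 ug/mL in this assay, at which 2 of the 2 values shown sit.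

Compound 3 `CC(C)(C)[Si](C)(C)Oc1ccc(-c2cc(=O)c3ccc(O)cc3o2)cc1` carries a group of 8 heavy atoms (6 carbon, 1 oxygen, 1 silicon; no ring) in place of one nitrogen atom, on an aromatic carbon. The new group stands on the same kind of site, para to a large group.

Among the compounds with values here, the only measured step that bears on this change is a step that the two limits leave unreadable from compound 1 to compound 2, which was also a change on an aromatic carbon. It offers no size to carry over, so the expectation rests on weak ground. In this assay a modest move toward lower numbers is expected, though a further limit remains quite possible. The expected change is an at least 1.3-fold lower number from compound 2 to compound 3 (0.14 log units; that floor lies within the scatter). The estimate for compound 3 is 18 ug/mL, with an expected range of 5 ug/mL to 40 ug/mL.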

Compound 3, concentration for half-maximal effect: > 10 ug/mL
Compound 3: a limit, no number; the forecaster's own chance of this, stated with the estimate: 55%; the middle value does not contradict the limit.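

In this assay compound 3 gives > 10 ug/mL, a limit and not a number. For the compounds shown here, compound 1 and compound 2 also stand as limits, and no step among compound 1, compound 2 and compound 3 can be read. Going by these compounds, whether any of the three reaches a half-maximal effect on these cells, and at what concentration, stays open.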